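Replacing an Ethylamide with a Piperidine Amide

A few compounds are considered here, and "the series" means these few. Any claim that something is new, unique, unknown or untested is made for them only; others in the source may bear on it.

Measured compounds:
- compound 1 `C[C@H]1CN(c2ncc(NC(=O)C3CC3)cc2Cl)CCN1C1CCN(Cc2ccc(Cl)cc2)CC1` gives 20 nM
- compound 2 `CCNC(=O)c1cnc(N2CCN(C3CCN(Cc4ccc(Cl)cc4)CC3)[C@@H](C)C2)c(Cl)c1` gives 2.3 nM

In a functional assay for antagonist activity at C-X-C chemokine receptor type 3 (Homo sapiens) (on this read-out higher numbers stand for weaker inhibition and lower numbers for stronger inhibition), compound 2 stands lowest of the two numbers. Within the data shown here, the single step measured so far is an 8.7-fold lower number from compound 1 to compound 2 (0.94 log units; beyond the scatter), a change of the group on the aromatic carbon. The next compound, compound 3 `C[C@H]1CN(c2ncc(C(=O)N3CCCCC3)cc2Cl)CCN1C1CCN(Cc2ccc(Cl)cc2)CC1`, differs from compound 2 at the carbonyl carbon instead: piperidin-1-yl in place of ethylamino on a carbonyl carbon. The ring that enters carries no hydrogen-bond donor, whereas the ethylamino group that leaves carried one. Among the measured compounds shown here, no measured step touches this position, so the step from compound 1 to compound 2 bears on it only by showing that changes around this amide can move the number well beyond the scatter. With nothing closer to rest on, a modest rise is expected, a 2.6-fold higher number from compound 2 to compound 3 (0.42 log units; beyond the scatter), so compound 3 is estimated at 6 nM, within a range of 1.5 nM to 30 nM.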

Compound 3, half-maximal inhibitory concentration: 900 nM
Beside the measured number, compound 3's estimate is 150-fold (2.18 log units) below it; the whole stated range lies below it.
By their numbers in this assay, from the lowest: compound 2; then compound 1; then compound 3.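

In this assay, the carbonyl carbon turns out to be far less forgiving than the earlier pair could show: piperidin-1-yl in place of ethylamino gives a 390-fold higher number from compound 2 to compound 3 (2.59 log units; beyond the scatter), the largest step in this set and one that removes all of the gain seen with the ethylcarbamoyl group. The (piperidin-1-yl)carbonyl group also compares poorly with (cyclopropylcarbonyl)amino on the aromatic carbon, with a 45-fold higher number from compound 1 to compound 3 (1.65 log units; beyond the scatter), so compound 3 has the highest number of the three. No available evidence accounts for this loss.

The change removes the amide hydrogen and adds a ring at once, so the two cannot be told apart here. Dimethylamino on the carbonyl carbon, with no amide hydrogen and no ring, or a longer chain on the amide nitrogen that keeps this hydrogen, would help to separate them.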